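A few compounds are considered here, and "the series" means these few. Any claim that something is new, unique, unknown or untested is made for them only; others in the source may bear on it.

In a functional assay on A-375 cells (Homo sapiens) for cytotoxicity, read by sulforhodamine B assay, with a stated time of 48 h (a higher number here means a weaker inhibitor, a lower number a stronger inhibitor), compound 1 `COc1cc(NC(=O)[C@@H]2CSC(c3ccccc3)N2)cc(OC)c1OC` gives > 100000 nM as a limit of the assay and not as a number. Going by the values given here, compound 2 `CCc1ccc(-c2nc(C(=O)c3cc(OC)c(OC)c(OC)c3)cs2)cc1` reads 17 nM and holds the only number so far. The next step leads to compound 3 `COC(=O)c1ccc(-c2nc(C(=O)c3cc(OC)c(OC)c(OC)c3)cs2)cc1` with methoxycarbonyl in place of ethyl on an aromatic carbon, para to a large group (methoxycarbonyl in place of ethyl on an aromatic carbon). Among the compounds with values here, no measured step bears on this change, so in this assay only a moderate rise of the number, meaning a weaker inhibitor, is expected, and its size is uncertain. The expected move is a 3.5-fold higher number from compound 2 to compound 3 (0.55 log units; beyond the scatter) on this estimate. For compound 3 the expected value is 60 nM (estimated range 15 nM to 300 nM).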

Compound 3, half-maximal inhibitory concentration: > 100000 nM
Compound 3 was reported as a limit (the forecaster's own chance of this, stated with the estimate: 3%); middle value at least 1600-fold (3.22 log units) from the limit.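

Going by these compounds alone, on an aromatic carbon para to a large group, this is the first single change that can be read, and the position proves far from indifferent to its substituent: in this assay, methoxycarbonyl in place of ethyl gives an at least 5800-fold higher number from compound 2 to compound 3 (3.76 log units; beyond the scatter). Ethyl is compatible with activity on the shared core, whereas methoxycarbonyl is not. Compound 3 stands at a limit of the assay, so the step gives only a minimum size: the limit of > 100000 nM in this assay, at which 2 of the 3 values shown sit.

On these data alone, whether the loss follows the carbonyl, the ester oxygens or the larger group remains open. Also open, as far as these compounds go, is how an amine, a carboxylic acid or a longer alkyl chain would read at this position.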